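Pyrrolidine nitrogen substituents: sulfonyl, free amine, isopropyl, carbamate

The source may report more compounds than this note shows. Statements on the series, on what has been measured and on what is new or still open speak of the compounds shown alone.

Measured compounds:
- compound 1, `CS(=O)(=O)N1C[C@H](C(=O)Nc2ccc(Cl)cc2)[C@@H](C(=O)Nc2ccc(-n3ccccc3=O)cc2F)C1`: 2.17 in a physicochemical assay for lipophilicity, at pH 7.4; on this read-out lower numbers stand for lower lipophilicity and higher numbers for higher lipophilicity
- compound 2, `O=C(Nc1ccc(Cl)cc1)[C@H]1CNC[C@@H]1C(=O)Nc1ccc(-n2ccccc2=O)cc1F`: "not determined" (no result reported) in this assay
- compound 3, `CC(C)N1C[C@H](C(=O)Nc2ccc(Cl)cc2)[C@@H](C(=O)Nc2ccc(-n3ccccc3=O)cc2F)C1`: "not determined" (no result reported) in this assay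

Among the compounds with values here, compound 1 is the only member of the series with a number in this assay; for compound 1 the read-out is 2.17. In this assay, within the data shown here, compound 2 gives "not determined" (no result reported) and compound 3 gives "not determined" (no result reported), so compound 3 stands nowhere on the numbers: its position in this assay is unknown, and no measured step can be compared with it.

Compound 4, `CCCOC(=O)N1C[C@H](C(=O)Nc2ccc(Cl)cc2)[C@@H](C(=O)Nc2ccc(-n3ccccc3=O)cc2F)C1`, differs from compound 3 in one place: propoxycarbonyl in place of isopropyl on an amine nitrogen in a ring. Among the measured compounds shown here, with no value for compound 3, the step from compound 3 to compound 4 cannot be anchored to data, and no step between measured compounds is available as a guide; the direction and size of the step in this assay therefore remain an open expectation rather than an extrapolation. For compound 4 the read-out in this assay is estimated at 3, with a range of 2.4 to 3.6.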

Compound 4, distribution coefficient: 3.06
Estimate against measurement, compound 4: 0.06 log units below; the measured number falls inside the stated range.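

In this assay the substituent on the amine nitrogen in the ring now has its first readable step: propoxycarbonyl in place of methylsulfonyl gives a number 0.89 log units higher from compound 1 to compound 4 (beyond the scatter). The read-out at this position therefore moves with the nitrogen substituent while the shared core stays the same. Nothing available accounts for the direction or size of this step.

Steps involving compound 2 or compound 3 cannot be read, so the free amine and isopropyl remain unplaced against the sulfonyl and the carbamate. As far as these compounds go, a single step sets no trend, and it stays open where an ethoxycarbonyl group, a longer carbamate chain or an acetyl group on the same nitrogen would fall in this assay.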